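Notes on a double-bond geometry step in the series

The compounds below may be only part of what the source reports. "The series", "measured", "known", "first", "only" and "open" are said of these compounds alone.

In a functional assay on BV-2 cells (Mus musculus) for inhibition, read by Griess assay, with a stated time of 24 h (on this read-out lower numbers stand for stronger inhibition and higher numbers for weaker inhibition), compound 1 `C[C@]12CCC[C@](C)(C(=O)O[C@@H]3O[C@H](CO)[C@@H](O)[C@H](O)[C@H]3O)[C@@H]1CC[C@](C)(O)[C@@H]2CCC1=CCOC1=O` gives 49200 nM, compound 2 `C=C1C[C@H](O)[C@@H]2[C@](C)(CCC[C@]2(C)C(=O)O[C@@H]2O[C@H](CO)[C@@H](O)[C@H](O)[C@H]2O)[C@H]1CCC1=CCOC1=O` gives 35700 nM and compound 3 `C=C1CC[C@@H]2[C@](C)(CCC[C@]2(C)C(=O)O[C@@H]2O[C@H](CO)[C@@H](O)[C@H](O)[C@H]2O)[C@H]1CC/C(=C/CO)CO` gives 152000 nM. Compound 3 thus stands with the highest number of the three; its gaps to compound 1 and to compound 2 both lie beyond the scatter, so on these data it is the weakest inhibitor. Compound 4 `C=C1CC[C@@H]2[C@](C)(CCC[C@]2(C)C(=O)O[C@@H]2O[C@H](CO)[C@@H](O)[C@H](O)[C@H]2O)[C@H]1CC/C(=C\CO)CO` is not yet tested. Relative to compound 3, (the two compounds have the same atoms and bonds and differ only in configuration as drawn: 1 of 10 stereo elements differ; a double bond is drawn Z in compound 3 and E in compound 4). For the measured compounds named here, no measured pair shows what such a change in geometry does in this assay, so the size and direction of the step are not known from the data. The step from compound 3 to compound 4 is expected to be small, within the scatter, at a 1.0-fold lower number from compound 3 to compound 4 (0.01 log units; within the scatter). Compound 4 is accordingly estimated at 150000 nM, within 60000 nM to 400000 nM.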

Compound 4, half-maximal inhibitory concentration: 65400 nM
Beside the measured number, compound 4's estimate is 2.3-fold (0.36 log units) above it; measured number inside the range.
By their numbers in this assay, from the lowest: compounds 2, 1 and 4 (each within the scatter of the next); then compound 3.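

Changing the double bond from Z to E gives a 2.3-fold lower number from compound 3 to compound 4 (0.37 log units; beyond the scatter) in this assay, so the geometry at this position matters modestly, with the E form the stronger inhibitor of this pair. The earlier compounds shown here offered no pair that isolated such a change. The step can be tied to the geometry alone on one ground: the fact that compounds 3 and 4 differ only in the configuration as drawn

The compounds shown leave open whether this preference for the E form persists when either hydroxymethyl group on the double bond is replaced by a carboxylic acid or an amine.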